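Moving the chlorine from compound 3 to compound 4

This account rests on a few compounds, and the source may have more. Where it says the series, first, only, none or still open, it means among the compounds named here.

In a functional assay on NCI-H460 cells (Homo sapiens) for inhibition, read by MTT assay, with a stated time of 24 h, tested at 100 ug/mL (a higher number here means more inhibition of growth at the concentration tested, a lower number less inhibition of growth), compound 1 `O=C(CCCCC(S)CCS)Nc1ccc(F)cc1` gives 41.6% and compound 2 `CC(=O)SCCC(CCCCC(=O)Nc1ccccc1)SC(C)=O` gives 44.8%, two values within the scatter of each other. Compound 3 `CC(=O)SCCC(CCCCC(=O)Nc1ccccc1Cl)SC(C)=O` gives 15.2%, the lowest of the three numbers and beyond the scatter from both others.

Compound 4 `CC(=O)SCCC(CCCCC(=O)Nc1ccc(Cl)cc1)SC(C)=O` is the next to be read. The change is 4-chlorophenyl in place of 2-chlorophenyl on an amide-type nitrogen, with the same atoms joined differently.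

Within the data shown here, only one measured step bears on this change: a number 29.6 percentage points lower from compound 2 to compound 3 (beyond the scatter), with chloro in place of hydrogen on an aromatic carbon. Among the measured compounds shown here, compound 1 takes part in no measured step that differs in one place, so it offers no direct guide. For the measured compounds named here, no measured pair separates the presence of the chlorine from the place it occupies. If the drop belongs to the 2-chlorophenyl group alone, the number should return towards that of compound 2 at 44.8%. If it follows the chlorine wherever it sits, the number should stay low. A partial recovery is the working expectation, and it is uncertain. The expected change is a number 15.8 percentage points higher from compound 3 to compound 4 (beyond the scatter). Compound 4 is estimated at 31%, with an expected range of 16% to 47%.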

Compound 4, percent growth inhibition at one concentration: 47.3%
Estimate against measurement, compound 4: 16.3 percentage points below; measured number above the stated range.
By their numbers in this assay, from the lowest: compound 3; then compounds 1, 2 and 4 (each within the scatter of the next).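

The isomer pair in this assay separates the place of the chlorine from its presence: a number 32.1 percentage points higher from compound 3 to compound 4 (beyond the scatter) with the same atoms joined differently, so among these compounds the low number goes with 2-chlorophenyl and not with chlorine as such. The second step, a number 2.5 percentage points higher from compound 2 to compound 4 (within the scatter), shows that chloro on the aromatic carbon of 4-chlorophenyl cannot be told apart from hydrogen in this read-out, so the cost seen in compound 3 does not follow the chlorine into compound 4. Nothing measured here accounts for the gap between the two chlorophenyl isomers.

Still open, as far as these compounds go, is whether the low number is particular to chlorine, since a methyl or methoxy group in place of the chlorine of 2-chlorophenyl would test whether another substituent in that place gives the same result. Compound 1 differs from the others in more than one place, so the contribution of the two acetyl groups on sulfur stays unresolved, and each reading remains a single concentration rather than a full dose-response.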